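The source may report more compounds than this note shows. Statements on the series, on what has been measured and on what is new or still open speak of the compounds shown alone.

Measured compounds:
Compound 1 `CNC1CCN(c2ncnc3c2cnn3CCN2CCCCC2)C1` gives 25800 nM in an assay on HEK293 cells for displacement of a labelled ligand from Sigma non-opioid intracellular receptor 1 (Homo sapiens), read by scintillation counting, with a stated time of 120 min; a higher number here means a weaker inhibitor, a lower number a stronger inhibitor.
Compound 2 `Cc1cccc(-c2ncnc3c2cnn3CCN2CCCCC2)c1` gives 82 nM in this assay.

For the measured compounds named here, compound 2 has the lower of the two numbers, and the only measured step, a 310-fold lower number from compound 1 to compound 2 (2.50 log units; beyond the scatter), separates it from compound 1. Compound 3 `N#Cc1ccc(-c2ncnc3c2cnn3CCN2CCCCC2)cc1` has not been measured yet. It differs from compound 2 in one place: 4-cyanophenyl in place of 3-methylphenyl on an aromatic carbon, so the change is a 4-cyanophenyl group in place of a 3-methylphenyl group on the shared core, where the two-ring system meets the six-membered ring with two nitrogen atoms. Going by the values given here, the only known step, from compound 1 to compound 2, swapped a 3-(methylamino)pyrrolidin-1-yl group for an aromatic ring and was large; it bears on the new step only loosely, since compound 3 keeps an aromatic ring and adds a nitrile. Among the compounds with values here, no measured pair shows how a nitrile on that ring acts. Compound 3 is therefore expected to stay closer to compound 2 than to compound 1, with a modest step estimated as a 2.4-fold higher number from compound 2 to compound 3 (0.39 log units; beyond the scatter). The estimate for compound 3 in this assay is 200 nM, expected to fall between 40 nM and 1000 nM.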

Compound 3, inhibition constant: 558 nM
Compound 3: middle estimate off by 2.8-fold (0.45 log units), on the low side, and the stated range covers the measured number.
By their numbers in this assay, from the lowest: compound 2; then compound 3; then compound 1.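

In this assay, the new result shows that this aromatic carbon of the shared core is sensitive to more than the presence of an aromatic ring: exchanging 3-methylphenyl for 4-cyanophenyl gives a 6.8-fold higher number from compound 2 to compound 3 (0.83 log units; beyond the scatter). That step is still smaller than the gain over the non-aromatic group, since replacing 3-(methylamino)pyrrolidin-1-yl with 4-cyanophenyl gives a 46-fold lower number from compound 1 to compound 3 (1.66 log units; beyond the scatter), so both aromatic rings shown here have lower numbers than compound 1. Nothing available explains why the number moved in either step.

The step from compound 2 to compound 3 changes both the group on the ring and its place on that ring, so it cannot separate the effect of swapping methyl for nitrile from the effect of moving the substituent. A 4-methylphenyl or a 3-cyanophenyl group would pull those two changes apart, while an unsubstituted phenyl ring would show whether either substituent raises or lowers the number relative to the bare ring.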